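A few compounds are considered here, and "the series" means these few. Any claim that something is new, unique, unknown or untested is made for them only; others in the source may bear on it.

Measured in an ADME assay on the whole organism with Oryza sativa as the target, tested at 10 uM; on this read-out higher numbers stand for a weaker effect at the one concentration tested and lower numbers for a stronger effect:
compound 1 `CCc1ccccc1NC(=O)N[C@@H](C)c1ccccc1`: 95%
compound 2 `CC(C)c1ccccc1NC(=O)N[C@@H](C)c1ccccc1`: 93%
compound 3 `C[C@H](NC(=O)Nc1ccccc1I)c1ccccc1`: 98%

Compound 1 stands second highest of the three numbers in this assay; nearest is compound 2, with a number 2 percentage points lower from compound 1 to compound 2 (within the scatter), and furthest is compound 3, with a number 3 percentage points higher from compound 1 to compound 3 (within the scatter). Compound 4 `CCc1cccc(CC)c1NC(=O)N[C@@H](C)c1ccccc1` differs from compound 1 by ethyl in place of hydrogen on an aromatic carbon, placed on the core ring ortho to a large group and meta to an ethyl group. Among the compounds with values here, the steps that bear on it all change alkyl groups on or near this ring: a number 2 percentage points lower from compound 1 to compound 2 (within the scatter), a number 3 percentage points higher from compound 1 to compound 3 (within the scatter) and a number 5 percentage points higher from compound 2 to compound 3 (within the scatter), each within the scatter. A step beyond the scatter is therefore not expected in this assay; the expected step is a number 1 percentage points lower from compound 1 to compound 4 (within the scatter). Compound 4 is estimated at 94%, in the range 85% to 100%.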

Compound 4, a percentage reported as activity, at one concentration (the size of the read-out at that concentration, not a potency): 83%
Compound 4: middle estimate off by 11 percentage points, on the high side; measured number below the stated range.
By their numbers in this assay, from the lowest: compounds 4, 2, 1 and 3 (each within the scatter of the next, the first and the last beyond it).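

Ethyl in place of hydrogen at this aromatic carbon gives a number 12 percentage points lower from compound 1 to compound 4 (beyond the scatter) in this assay and is the first step in the series beyond the scatter, toward the stronger effect. The earlier steps shown here all changed the group already on the ring and stayed within the scatter, so this second ethyl group on the ring shifts the read-out where those changes did not. Nothing measured here accounts for the step.

Open, going by these compounds, is whether methyl or a longer chain such as propyl at this carbon gives a step of similar size. Also open, on these data alone, is whether an amine or a hydroxyl group there keeps the stronger effect.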